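Series notes: lipophilicity, step from compound 3 to compound 4

A few compounds are considered here, and "the series" means these few. Any claim that something is new, unique, unknown or untested is made for them only; others in the source may bear on it.

Measured so far:
compound 1 `C[C@H](Oc1ccc2ncc(/C=C/C(N)=O)c(C3CC3)c2c1)c1c(Cl)ccc(F)c1Cl`, > 5.5
compound 2 `C[C@H](Oc1ccc(/C=C/C(=O)O)cc1)c1c(Cl)ccc(F)c1Cl`, 2.8
compound 3 `C[C@H](Oc1cccc(C2CC2)n1)c1c(Cl)ccc(F)c1Cl`, 4.9

All three share the chiral ether of the dichloro-fluorophenyl unit and differ in the core it is attached to. In a physicochemical assay for lipophilicity, using the shake flask method (a higher number here means a more lipophilic compound, a lower number a more polar compound), compound 1 reaches only a limit, > 5.5, not a number; (the limit of > 5.5 in this assay, at which 1 of the 3 values shown sits). Compound 2 gives 2.8 in this assay. Compound 3 gives 4.9 in this assay, the highest of the two numbers, with compound 2 lying lower by a gap that is beyond the scatter. Among the compounds with values here, no step between two measured compounds differs in only one place, so no measured step is available.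

Compound 4 `C[C@H](Oc1ccc(NC(=O)CC(=O)O)c(C2CC2)n1)c1c(Cl)ccc(F)c1Cl` is not yet measured. It differs from compound 3 as follows: ((carboxymethyl)carbonyl)amino in place of hydrogen on an aromatic carbon. Within the data shown here, no measured pair shows this change. The expectation is a step downward in this assay from compound 3 to compound 4 of about a number 2.10 log units lower from compound 3 to compound 4 (beyond the scatter), clearly beyond the scatter, with compound 2 at 2.8 as the nearest reference point among the numbers. Compound 4 is thus estimated at 2.8, with a range from 2 to 3.7.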

Compound 4, distribution coefficient: 1.4
Compound 4: middle estimate off by 1.40 log units, on the high side; measured number outside the range, below it.
By their numbers in this assay, from the lowest: compound 4; then compound 2; then compound 3. At a limit, above all of these: compound 1.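

In this assay, ((carboxymethyl)carbonyl)amino in place of hydrogen, on the aromatic carbon ortho to a cyclopropyl group and two atoms from the ring nitrogen, gives a number 3.50 log units lower from compound 3 to compound 4 (beyond the scatter). Within the data shown here, this is the first measured step that differs in one place, and it shows that the read-out at this position responds strongly to this change, which the earlier compounds could not show. Nothing measured here bears on the cause of a step of this size.

From the compounds shown here alone, how much of the step belongs to the chain's end and how much to the amide part stays open, as a plain amino group, an acetylamino group or the methyl ester of this chain at the same carbon would tell these apart. Going by these compounds, whether a longer chain, or this chain on another ring carbon, gives a similar step is also open.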